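A few compounds are considered here, and "the series" means these few. Any claim that something is new, unique, unknown or untested is made for them only; others in the source may bear on it.

- compound 1 `Cc1cccc2c1CC/C2=C\C(=O)NC1CC1` gives 64 mg/kg
- compound 2 `O=C(/C=C1\CCc2ccccc21)NC1CC1` gives 235 mg/kg

Both numbers come from a functional assay on the whole organism with Mus musculus as the target, in the rotarod test (on this read-out higher numbers stand for an effect only at larger amounts of compound and lower numbers for an effect already at smaller amounts), and compound 2 holds the higher of the two. Compound 3 `O=C(/C=C1\CCc2ccc(F)cc21)NC1CC1` has not been measured and differs from compound 2 by fluoro in place of hydrogen on an aromatic carbon in the form of fluoro in place of hydrogen on an aromatic carbon. That carbon lies meta to a fused ring and para to a fused ring.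

For the measured compounds named here, the only measured step is a 3.7-fold higher number from compound 1 to compound 2 (0.56 log units; beyond the scatter) and it goes with hydrogen in place of methyl on an aromatic carbon. Going by the values given here, it bears on the new change only loosely, since it concerns methyl and not fluoro, and no measured pair shows what fluoro does. Among the compounds with values here, with compound 1 at 64 mg/kg as the sole substituted comparison, a modest step towards a lower number is expected, no larger than the measured one, and a result within the scatter would fit as well. The expectation is a 1.6-fold lower number from compound 2 to compound 3 (0.19 log units; within the scatter) and it remains an estimate. Compound 3 is expected at 150 mg/kg within an estimated range from 65 mg/kg to 340 mg/kg for a single measurement.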

Compound 3, dose for half-maximal effect: 62 mg/kg
Estimate against measurement, compound 3: 2.4-fold (0.38 log units) above, and the stated range ends above it.
By their numbers in this assay, from the lowest: compounds 3 and 1 (each within the scatter of the next); then compound 2.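

In this assay, fluoro in place of hydrogen on this aromatic carbon, meta to a fused ring and para to a fused ring, goes with a 3.8-fold lower number from compound 2 to compound 3 (0.58 log units; beyond the scatter), so this position responds to a single added fluorine by more than the scatter. For the compounds shown here, until now, the only measured change on the aromatic ring involved methyl on a different carbon, a 3.7-fold higher number from compound 1 to compound 2 (0.56 log units; beyond the scatter), and it said nothing about fluoro or this position. Compound 2 now has a single-change neighbour on each of these two aromatic carbons, and in both pairs the compound carrying hydrogen has the higher number, although two pairs are too few to make a rule and no measurement shown explains either step.

The compounds shown do not tell whether this step is particular to fluoro or would also appear with chloro, methoxy or methyl on the same carbon, or with fluoro on another carbon of the ring. They also leave open how the read-out would respond to an amine or a longer chain on the amide nitrogen in place of its present group.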